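Acetylating the Phenol Oxygen of Compound 2

A few compounds are considered here, and "the series" means these few. Any claim that something is new, unique, unknown or untested is made for them only; others in the source may bear on it.

Of the compounds shown here, three with a shared core have been tested in a functional assay on PC-3 cells (Homo sapiens) for cytotoxicity, read by MTT assay, with a stated time of 48 h; a higher number here means a weaker inhibitor, a lower number a stronger inhibitor. Compound 1 `CC1=NN(C(=O)COc2ccc(Cl)cc2)C(c2ccccc2O)C1` gives 38800 nM; compound 2 `CC1=NN(C(=O)CN2CCCCC2)C(c2ccccc2O)C1` gives 5890 nM; compound 3 `CC1=NN(C(=O)CN2CCCC2)C(c2ccccc2O)C1` gives 6670 nM. Compound 2 shows the lowest of the three numbers, though compound 3 lies within the scatter of it, while compound 1 lies beyond it. The steps beyond the scatter, a 6.6-fold lower number from compound 1 to compound 2 (0.82 log units; beyond the scatter) and a 5.8-fold lower number from compound 1 to compound 3 (0.76 log units; beyond the scatter), concern the group on the saturated chain carbon bound to the carbonyl carbon, whereas a 1.1-fold higher number from compound 2 to compound 3 (0.05 log units; within the scatter). Compound 4 `CC(=O)Oc1ccccc1C1CC(C)=NN1C(=O)CN1CCCCC1` differs from compound 2 elsewhere: acetyl in place of hydrogen on an oxygen on an aromatic ring, hydroxy to acetoxy. Going by the values given here, no measured step touches this oxygen, so no step beyond the scatter is expected, a 1.2-fold higher number from compound 2 to compound 4 (0.07 log units; within the scatter). For compound 4 the estimate is 7000 nM, ranging from 2500 nM to 20000 nM.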

Compound 4, half-maximal inhibitory concentration: 4070 nM
Estimate against measurement, compound 4: 1.7-fold (0.24 log units) above; low and high end bracket the measured number.
By their numbers in this assay, from the lowest: compounds 4, 2 and 3 (each within the scatter of the next); then compound 1.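

In this assay, acetyl in place of hydrogen on the oxygen on the aromatic ring gives a 1.4-fold lower number from compound 2 to compound 4 (0.16 log units; within the scatter) and nothing beyond the scatter. Hydroxy to acetoxy at this oxygen therefore leaves the number unresolved from that of the free phenol, at least with piperidin-1-yl on the chain. No measured evidence bears on why this is so.

As far as these compounds go, whether a methyl ether or a benzoyl ester on this oxygen would read the same remains open. So does whether acetoxy behaves alike with pyrrolidin-1-yl or 4-chlorophenoxy on the chain.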